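Phenoxy for benzyl on the saturated ring carbon

The compounds below may be only part of what the source reports. "The series", "measured", "known", "first", "only" and "open" are said of these compounds alone.

In a physicochemical assay for lipophilicity, measured as chromatographic lipophilicity, at pH 7.4 (on this read-out higher numbers stand for higher lipophilicity and lower numbers for lower lipophilicity), compound 3 (`COc1cc(-c2nnc3n2CCCC3(Cc2ccc(F)c(F)c2)C(C)(C)O)ccc1-c1cnc(C)o1`) stands at 3 and lies within the scatter of compound 2 (`COc1cc(-c2nnc3n2CCCC3(c2ccc(F)c(F)c2)C(C)(C)O)ccc1-c1cnc(C)o1`) at 2.9 with a number 0.10 log units higher from compound 2 to compound 3 (within the scatter) as the step between them. Compound 1 (`COc1cc(-c2nnc3n2CCCC3(c2ccc(Cl)c(Cl)c2)C(C)(C)O)ccc1-c1cnc(C)o1`) at 3.7 is the highest of the three numbers, and the steps away from it are a number 0.80 log units lower from compound 1 to compound 2 (beyond the scatter) and a number 0.70 log units lower from compound 1 to compound 3 (beyond the scatter) in the series.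

Within the data shown here, compound 4 (`COc1cc(-c2nnc3n2CCCC3(Oc2ccc(F)c(F)c2)C(C)(C)O)ccc1-c1cnc(C)o1`) carries 3,4-difluorophenoxy in place of 3,4-difluorobenzyl on a saturated ring carbon as its only change: 3,4-difluorophenoxy in place of 3,4-difluorobenzyl on a saturated ring carbon. Among the measured compounds shown here, no measured step introduces the phenoxy group. The nearest guide is the exchange of 3,4-difluorophenyl for 3,4-difluorobenzyl, seen as a number 0.10 log units higher from compound 2 to compound 3 (within the scatter) here, while the larger steps from compound 1 involve the 3,4-dichlorophenyl group, which is absent from this pair. The estimated change is a number 0.10 log units higher from compound 3 to compound 4 (within the scatter) and nothing beyond the scatter is expected in this assay for this exchange. For compound 4 the estimated value is 3.1 within an expected range of 2.7 to 3.5 on this read-out.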

Compound 4, distribution coefficient: 2.8
Compound 4: the middle estimate sits 0.30 log units above what was measured, within the range that was stated.
By their numbers in this assay, from the lowest: compounds 4, 2 and 3 (each within the scatter of the next); then compound 1.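

At the saturated ring carbon, the 3,4-difluorophenoxy group now joins 3,4-difluorobenzyl and 3,4-difluorophenyl in one band of this assay, with a number 0.20 log units lower from compound 3 to compound 4 (within the scatter) and a number 0.10 log units lower from compound 2 to compound 4 (within the scatter) as the two steps. The hydrogen-bond acceptor counted in the entering 3,4-difluorophenoxy group, absent from the leaving 3,4-difluorobenzyl group, comes with no step beyond the scatter, while the exchange from 3,4-dichlorophenyl again gives one (a number 0.90 log units lower from compound 1 to compound 4 (beyond the scatter)). Nothing available explains this pattern.

Open, going by these compounds, is whether 3,4-dichlorophenoxy on this carbon would sit with compound 1 or with compound 4. Also open, on these data alone, is how this assay responds at this position to an amine, a carboxylic acid or a longer chain.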